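A Sulfamoyl Group Replaces Chloro on Compound 3

A few compounds are considered here, and "the series" means these few. Any claim that something is new, unique, unknown or untested is made for them only; others in the source may bear on it.

Among the measured compounds shown here, three thioureas have numbers so far. In a functional assay on MDA-MB-231 cells (Homo sapiens) for inhibition, read by MTT assay, with a stated time of 48 h (a lower number here means a stronger inhibitor of growth, a higher number a weaker inhibitor of growth), compound 1 `CC(C)c1ccc(Nc2ncnc3ccc(NC(=S)NCc4ccccc4)cc23)cc1` gives 12800 nM, compound 2 `S=C(Nc1ccccc1)Nc1ccc2ncnc(Nc3cccc(Br)c3)c2c1` gives 10000 nM and compound 3 `S=C(Nc1ccc(Cl)cc1)Nc1ccc2ncnc(Nc3cccc(Br)c3)c2c1` gives 8200 nM. These three results lie within the usual scatter of one another, so compound 3 stands level with the other two and cannot be separated from them on this evidence.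

The next compound is compound 4 `NS(=O)(=O)c1ccc(NC(=S)Nc2ccc3ncnc(Nc4cccc(Br)c4)c3c2)cc1`, which has sulfamoyl in place of chloro on an aromatic carbon, para to a large group: sulfamoyl in place of chloro on an aromatic carbon. The same difference, cut one bond further out, reads 4-chlorophenyl to 4-sulfamoylphenyl.

For the measured compounds named here, only one measured step bears on this change. It is a 1.2-fold lower number from compound 2 to compound 3 (0.09 log units; within the scatter), where chloro takes the place of hydrogen, and it stays within the scatter. Going by the values given here, that step shows little response to one substituent at a single site, but no measured compound carries a sulfamoyl group, so the data offer only weak guidance. No step beyond the scatter is therefore expected in this assay, and the expected step is a 1.2-fold lower number from compound 3 to compound 4 (0.07 log units; within the scatter). For compound 4 the estimated value is 7000 nM, with an expected range from 2500 nM to 18000 nM.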

Compound 4, concentration for 50% growth inhibition: > 30000 nM
Compound 4 gave a limit, no number; the forecaster's own chance of this, stated with the estimate: 8%; middle value at least 4.2-fold (0.63 log units) from the limit.
By their numbers in this assay, from the lowest: compounds 3, 2 and 1 (each within the scatter of the next). At a limit, above all of these: compound 4.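

In this assay the reading for compound 4 is a limit and not a number: the limit of > 30000 nM in this assay, at which 1 of the 4 values shown sits. The earlier compounds shown here gave no sign that this aromatic carbon responds to its substituent, as chloro in place of hydrogen left the two values within the scatter, with a 1.2-fold lower number from compound 2 to compound 3 (0.09 log units; within the scatter), whereas sulfamoyl gives an at least 3.6-fold higher number from compound 3 to compound 4 (0.56 log units; beyond the scatter) and an at least 3.0-fold higher number from compound 2 to compound 4 (0.47 log units; beyond the scatter). The position is therefore not indifferent to what it carries, and among these three compounds, which differ only there, the 4-sulfamoylphenyl group is the one that stands apart, as the weaker inhibitor of growth, by a margin that the limit leaves without an upper bound.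

With only one group beyond the scatter, the compounds shown cannot say whether this loss belongs to the sulfamoyl group alone or would also follow from a methylsulfonyl group, a carboxylic acid or an amine on the same carbon. They also leave open whether sulfamoyl would have the same effect on the benzyl thiourea of compound 1, which differs from these compounds in more than one place.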